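A Single Fluoro Added to the Phenyl of Compound 2

A few compounds are considered here, and "the series" means these few. Any claim that something is new, unique, unknown or untested is made for them only; others in the source may bear on it.

Measured compounds:
compound 1, `Cc1c(C(=O)Nc2ccc(Oc3ccnc4[nH]ccc34)c(F)c2)nnn1-c1ccccc1F`, 3240 nM
compound 2, `Cc1c(C(=O)Nc2ccc(Oc3ccnc4[nH]ccc34)cc2)nnn1-c1ccccc1`, 7260 nM

In a functional assay on PC-3 cells (Homo sapiens) for cytotoxicity, read by MTT assay, with a stated time of 72 h (a higher number here means a weaker inhibitor, a lower number a stronger inhibitor), compound 1 gives 3240 nM while compound 2 gives 7260 nM. Compound 2 thus holds the higher of the two numbers, and the gap to compound 1 lies beyond the scatter. Compound 3, `Cc1c(C(=O)Nc2ccc(Oc3ccnc4[nH]ccc34)cc2)nnn1-c1ccccc1F`, differs from compound 2 by fluoro in place of hydrogen on an aromatic carbon, phenyl to 2-fluorophenyl. For the measured compounds named here, no measured pair isolates this change; compound 1 carries a second fluoro elsewhere, so its lower number cannot be credited to either change alone. In this assay a modest move toward a lower number is expected for compound 3, possibly within the scatter. The estimate for compound 3 is 5000 nM, range 2500 nM to 10000 nM, an expected step of a 1.5-fold lower number from compound 2 to compound 3 (0.16 log units; within the scatter).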

Compound 3, half-maximal inhibitory concentration: 3450 nM
Estimate against measurement, compound 3: 1.4-fold (0.16 log units) above, within the range that was stated.
By their numbers in this assay, from the lowest: compounds 1 and 3 (each within the scatter of the next); then compound 2.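

In this assay the fluoro on the phenyl now has a step of its own, a 2.1-fold lower number from compound 2 to compound 3 (0.32 log units; beyond the scatter), modest but beyond the scatter. The second fluoro that separates the other pair can be read as well: a 1.1-fold higher number from compound 1 to compound 3 (0.03 log units; within the scatter), a step within the scatter, so that difference does not set these compounds apart. Nothing measured here accounts for either step. Open, going by these compounds, is how a chloro group, a methoxy group or an amine would fare in place of this fluoro, and whether fluoro on another carbon of the phenyl would give a similar step.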